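The compounds below may be only part of what the source reports. "The series", "measured", "known", "first", "only" and "open" are said of these compounds alone.

Measured compounds:
- compound 1 `COc1ncnc2c1c(I)cn2[C@@H]1O[C@H](CO)[C@@H](O)[C@H]1O`: > 20000 nM
- compound 2 `Cc1ncnc2c1c(-c1cccs1)cn2[C@@H]1O[C@H](CO)[C@@H](O)[C@H]1O`: > 15000 nM
- compound 3 `Cc1ncnc2c1c(-c1ccsc1)cn2[C@@H]1O[C@H](CO)[C@@H](O)[C@H]1O`: 4720 nM

In a functional assay on HepG2 cells (Homo sapiens) for antiproliferative activity, read by XTT assay, with a stated time of 72 h (a higher number here means a weaker inhibitor, a lower number a stronger inhibitor), compound 1 reaches only > 20000 nM, which is a limit of the assay and not a number. Compound 2 likewise gives > 15000 nM in this assay, again a limit rather than a number. Compound 3 gives 4720 nM in this assay, the only true number among the three, so compound 3 is the one compound shown with a measured inhibitory concentration. Going by the values given here, the single measured step, an at least 3.1-fold lower number from compound 2 to compound 3 (0.50 log units; beyond the scatter), came from thiophen-3-yl in place of thiophen-2-yl on an aromatic carbon.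

Compound 4 `Cc1ncnc2c1c(I)cn2[C@@H]1O[C@H](CO)[C@@H](O)[C@H]1O` differs from compound 3 by iodo in place of thiophen-3-yl on an aromatic carbon. Among the compounds with values here, no measured step covers this change: the thiophen-3-yl for thiophen-2-yl step concerns two thiophene isomers and says nothing about iodo. Compound 1 also carries iodo on an aromatic carbon of the shared core and sits at a limit, which is the closest hint available. The expectation is therefore that compound 4 is weaker than compound 3, with an estimated step of a 3.2-fold higher number from compound 3 to compound 4 (0.50 log units; beyond the scatter) in this assay. Compound 4 is expected at about 15000 nM, within roughly 5000 nM to 60000 nM, and quite possibly only a limit.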

Compound 4, half-maximal inhibitory concentration: 3460 nM
Estimate against measurement, compound 4: 4.3-fold (0.64 log units) above, outside the stated range (below it).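

In this assay, a single iodine atom and a whole five-membered aromatic ring prove interchangeable at this position on the shared core, since the change stays within the scatter: a 1.4-fold lower number from compound 3 to compound 4 (0.13 log units; within the scatter). The thiophen-2-yl group is the one that stands apart among these three groups, as replacing it with iodo gives an at least 4.3-fold lower number from compound 2 to compound 4 (0.63 log units; beyond the scatter), a step whose true size is unknown, as compound 2 gives only a limit and not a number: the limit of > 15000 nM in this assay, at which 1 of the 4 values shown sits. Iodo at this position is also not enough on its own, since compound 1 carries it too and the change elsewhere on the core, methyl for methoxy on an aromatic carbon, gives an at least 5.7-fold lower number from compound 1 to compound 4 (0.76 log units; beyond the scatter), again with only a limit and not a number for compound 1: the limit of > 20000 nM in this assay, at which 1 of the 4 values shown sits.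

The compounds shown leave open whether this position accepts groups of a different kind, such as an amine, a carboxylic acid or a phenyl ring, as readily as it accepts iodo and thiophen-3-yl. They also leave open whether a longer chain such as ethyl, in place of the methyl, would keep or change the activity of compound 3 and compound 4.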